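The source may report more compounds than this note shows. Statements on the series, on what has been measured and on what is new or still open speak of the compounds shown alone.

Measured compounds:
Compound 1 `COc1ccc(/C=C/C(=O)c2cc(-c3cc(OC)c(OC)c(OC)c3)n3nc(-c4ccccc4)cc3n2)cc1OC` gives 41000 nM in an ADME assay on HEK293 cells (Homo sapiens) for antiproliferative activity, read by MTT assay, with a stated time of 24 h; on this read-out higher numbers stand for weaker inhibition and lower numbers for stronger inhibition.
Compound 2 `COc1cc(-c2cc(C(=O)/C=C/c3ccc(C)cc3)nc3cc(-c4ccccc4)nn23)cc(OC)c1OC` gives 56100 nM in this assay.
Compound 3 `COc1ccc(-c2cc(C(=O)/C=C/c3ccc(C)cc3)nc3cc(-c4ccccc4)nn23)cc1OC` gives 57400 nM in this assay.

Compound 2 stands second highest of these three numbers, and both gaps around it are small: a 1.0-fold higher number from compound 2 to compound 3 (0.01 log units; within the scatter), and a 1.4-fold higher number from compound 1 to compound 2 (0.14 log units; within the scatter).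

Compound 4 `COc1ccc(C(=O)/C=C/c2cc(-c3cc(OC)c(OC)c(OC)c3)n3nc(-c4ccccc4)cc3n2)cc1` has not been measured. It differs from compound 2 in one place: 2-((4-methoxyphenyl)carbonyl)ethenyl in place of (2-(4-methylphenyl)ethenyl)carbonyl on an aromatic carbon. Among the measured compounds shown here, no measured step makes this exact change. The step of a 1.4-fold higher number from compound 1 to compound 2 (0.14 log units; within the scatter) altered the same part of the structure and stayed within the scatter, and the step of a 1.0-fold higher number from compound 2 to compound 3 (0.01 log units; within the scatter) also stayed within the scatter. A step in this assay beyond the scatter is therefore not expected. Compound 4 is estimated at 50000 nM, with a range of 20000 nM to 120000 nM, which means an expected 1.1-fold lower number from compound 2 to compound 4 (0.05 log units; within the scatter).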

Compound 4, half-maximal inhibitory concentration: 79800 nM
The estimate for compound 4 lay 1.6-fold (0.20 log units) below the measured number; measured number inside the range.
By their numbers in this assay, from the lowest: compounds 1, 2, 3 and 4 (each within the scatter of the next).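

Earlier steps changed only the groups on the rings, whereas this one also reverses the chain, so that the ethenyl end rather than the carbonyl is bound to the aromatic carbon, and a methoxy replaces the methyl on the end ring. In this assay this gives (a 1.4-fold higher number from compound 2 to compound 4 (0.15 log units; within the scatter)), so even this larger change at this position stays within the scatter. No measured evidence bears on this result. The compounds shown leave open how this position would read with an amine or a carboxylic acid in place of the chain.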